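Notes on a chlorobenzyl sulfanyl pair in the artery series

A few compounds are considered here, and "the series" means these few. Any claim that something is new, unique, unknown or untested is made for them only; others in the source may bear on it.

Of the compounds shown here, two have been measured. Compound 1 `CC1=C(C(=O)Nc2ccc([N+](=O)[O-])cc2)C(c2ccc(Br)cc2)N=C(SCc2cccc(Cl)c2)N1` carries a (3-chlorobenzyl)sulfanyl group on the shared core, and compound 2 `CC1=C(C(=O)Nc2ccc([N+](=O)[O-])cc2)C(c2cccc([N+](=O)[O-])c2)N=C(SCc2ccccc2Cl)N1` carries a (2-chlorobenzyl)sulfanyl group together with a different aryl group on the core. In a functional assay on the whole organism (artery, strain albino) with Rattus norvegicus as the target, with a stated time of 180 min, at a dose of 10 mg/kg by the oral route (on this read-out lower numbers stand for less inhibition and higher numbers for more inhibition at the one dose given (going by the name of the read-out)), compound 1 gives 9.3%, and compound 2 gives 9.3%. Compound 2 therefore stands level with compound 1 at the digits reported, the two values lying within the scatter of each other. Going by the values given here, no pair of measured compounds differs in only one place, so no single-step comparison is available.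

Compound 3 `CC1=C(C(=O)Nc2ccc([N+](=O)[O-])cc2)C(c2cccc([N+](=O)[O-])c2)N=C(SCc2cccc(Cl)c2)N1` has not been measured. It differs from compound 2 as follows: 3-chlorophenyl in place of 2-chlorophenyl on a saturated chain carbon bound to a sulfur. This change returns the (3-chlorobenzyl)sulfanyl group found in compound 1, while keeping the aryl group of compound 2. Since compound 1 gives 9.3% and compound 2 gives 9.3%, nothing in the data points to a change beyond the scatter, and the expected step is no change at the digits printed from compound 2 to compound 3 (within the scatter). Compound 3 is estimated to give 9.3% in this assay, with a range from 0% to 20%.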

Compound 3, a percentage reported as inhibition, in the whole organism at one dose (the size of the read-out at that dose, not a potency): 14.9%
Compound 3: middle estimate off by 5.6 percentage points, on the low side; the range from low to high includes it.
By their numbers in this assay, from the lowest: compounds 1, 2 and 3 (each within the scatter of the next).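

Working from the first single-place comparisons in this assay, 3-chlorophenyl in place of 2-chlorophenyl on a saturated chain carbon bound to a sulfur gives a number 5.6 percentage points higher from compound 2 to compound 3 (within the scatter) with the rest of the structure held constant, so this position does not separate the two chlorobenzyl groups on the present numbers. At the saturated ring carbon, 3-nitrophenyl in place of 4-bromophenyl gives a number 5.6 percentage points higher from compound 1 to compound 3 (within the scatter) with the (3-chlorobenzyl)sulfanyl group held constant, so this exchange also stays inside the scatter, and neither of the two places has yet produced a step that can be read as a real difference. No supporting measurement is available to explain either step.

From the compounds shown here alone, whether the sulfur-bound position responds to a larger change remains open, since both groups compared there are chlorobenzyl groups; a 4-chlorobenzyl group, an unsubstituted benzyl group, a benzyl group carrying an amine or a carboxylic acid, or a longer chain ending in phenyl would test this. Going by these compounds, it is also open whether the ring-carbon aryl group matters more with other substituents, such as a methoxy group or a hydroxyl group, and whether any of these comparisons holds at other doses or times.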